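The source may report more compounds than this note shows. Statements on the series, on what has been measured and on what is new or still open speak of the compounds shown alone.

The measured compounds:

compound 1, `CCCCNC(=O)[C@@H](NC(=O)c1cccc(Cn2ccnc2)c1)[C@@H](C)CC`, in an assay on HEK293 cells for displacement of a labelled ligand from Type-2 angiotensin II receptor (Homo sapiens), tested at 10 uM (a lower number here means a weaker effect, a higher number a stronger effect of the compound at the concentration tested), compound 1 gives 3%
compound 2, `CC[C@H](C)[C@H](NC(=O)c1cccc(Cn2ccnc2)c1)C(=O)NNS(=O)(=O)c1ccccc1`, compound 2 gives 18%
compound 3, `CC[C@H](C)[C@H](NC(=O)c1cccc(Cn2ccnc2)c1)C(=O)NNS(=O)(=O)c1ccc(OC)cc1`, compound 3 gives 20%

Compound 2 stands second highest of these three numbers. Its nearest neighbour is compound 3, a step of a number 2 percentage points higher from compound 2 to compound 3 (within the scatter); compound 1 lies furthest away, the step of a number 15 percentage points higher from compound 1 to compound 2 (beyond the scatter) reaching beyond the scatter. Compound 4, `CC[C@H](C)[C@H](NC(=O)c1cccc(Cn2ccnc2)c1)C(=O)NS(=O)(=O)c1ccccc1`, has not yet been measured in this assay. It differs from compound 2 in one place: phenylsulfonyl in place of (phenylsulfonyl)amino on an amide-type nitrogen.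

Among the compounds with values here, two measured steps bear on this change. The step of a number 15 percentage points higher from compound 1 to compound 2 (beyond the scatter) shows that what hangs on this amide-type nitrogen can move the number beyond the scatter, though only modestly. The step of a number 2 percentage points higher from compound 2 to compound 3 (within the scatter), a change at the far end of the same group, stayed within the scatter. Neither step shortens the link as the change to compound 4 does, so no direct guide exists. A step within the scatter, in either direction, is expected. The expected step is a number 3 percentage points lower from compound 2 to compound 4 (within the scatter). Compound 4 is estimated at 15%, between 0% and 35%.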

Compound 4, a percentage reported as inhibition, at one concentration (the size of the read-out at that concentration, not a potency): 24%
Estimate against measurement, compound 4: 9 percentage points below; the measured number falls inside the stated range.
By their numbers in this assay, from the lowest: compound 1; then compounds 2, 3 and 4 (each within the scatter of the next).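

Shortening the link by one amino unit, so that phenylsulfonyl sits directly on the amide-type nitrogen, gives a number 6 percentage points higher from compound 2 to compound 4 (within the scatter) in this assay and so cannot be told apart from no change. This position therefore tolerates losing that link atom and its hydrogen-bond donor, at least at this modest level of effect. Set against butyl, phenylsulfonyl gives a number 21 percentage points higher from compound 1 to compound 4 (beyond the scatter) and remains clearly separated, so the sulfonyl-bearing groups in compound 2 and compound 4 both stand apart from butyl, with or without the link.

No measurement here explains these numbers. From the compounds shown here alone, whether the phenyl ring itself matters stays open, and a methylsulfonyl group or a carboxylic acid at this position would test how much of the phenylsulfonyl group is needed.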